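This account rests on a few compounds, and the source may have more. Where it says the series, first, only, none or still open, it means among the compounds named here.

Working notes on the series.

The shared core carries a sulfonylurea and a carbonyl whose substituent varies. Compound 1 `NNC(=O)c1c(NC(=O)NS(=O)(=O)c2ccccc2)sc2c1CCCCC2` bears a free hydrazide; in a functional assay on cells (Cancer cell lines, Homo sapiens) for inhibition, with a stated time of 48 h (a higher number here means a weaker inhibitor of growth, a lower number a stronger inhibitor of growth), compound 1 gives only a limit, > 100000 nM (the limit of > 100000 nM in this assay, at which 1 of the 3 values shown sits). Compound 2 `O=C(Nc1sc2c(c1C(=O)NNc1ccccc1)CCCCC2)NS(=O)(=O)c1ccccc1` has phenyl on the terminal nitrogen and in this assay compound 2 gives 30900 nM. Compound 3 `O=C(Nc1sc2c(c1C(=O)NNc1ccc(Br)cc1)CCCCC2)NS(=O)(=O)c1ccccc1` carries 4-bromophenyl there and in this assay compound 3 gives 25500 nM. The step of an at least 3.2-fold lower number from compound 1 to compound 2 (0.51 log units; beyond the scatter) and the step of an at least 3.9-fold lower number from compound 1 to compound 3 (0.59 log units; beyond the scatter) both lie beyond the scatter; the step of a 1.2-fold lower number from compound 2 to compound 3 (0.08 log units; within the scatter) lies within it, so compound 3 and compound 2 stand together, with compound 1 behind at its limit.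

Compound 4 `O=C(Nc1sc2c(c1C(=O)N1CCN(c3ccccc3)CC1)CCCCC2)NS(=O)(=O)c1ccccc1` introduces (4-phenylpiperazin-1-yl in place of ((4-bromophenyl)amino)amino on a carbonyl carbon). For the measured compounds named here, no measured step covers this exchange: the aromatic ring is kept, but the hydrazide with its two donors is replaced by a piperazine link without donors. The two aryl-bearing steps from compound 1 suggest the aryl group matters more than the donors, so a step of about a 1.0-fold lower number from compound 3 to compound 4 (0.01 log units; within the scatter) is expected, that is little change beyond the scatter. Compound 4 is estimated at 25000 nM, within 6000 nM to 90000 nM.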

Compound 4, concentration for 50% growth inhibition: 55800 nM
Estimate against measurement, compound 4: 2.2-fold (0.35 log units) below; measured number inside the range.
By their numbers in this assay, from the lowest: compounds 3, 2 and 4 (each within the scatter of the next, the first and the last beyond it). At a limit, above all of these: compound 1.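

At this carbonyl carbon, 4-phenylpiperazin-1-yl keeps the aromatic ring of the earlier aryl hydrazides but carries no hydrogen-bond donors, and in this assay the outcome depends on the comparison. Against the brominated partner there is a 2.2-fold higher number from compound 3 to compound 4 (0.34 log units; beyond the scatter), a modest step, whereas against the unsubstituted phenyl partner there is a 1.8-fold higher number from compound 2 to compound 4 (0.26 log units; within the scatter), so the donors of the hydrazide link are not shown to be required for the growth inhibition seen here. Against the free hydrazide there is an at least 1.7-fold lower number from compound 1 to compound 4 (0.25 log units; that floor lies within the scatter), a floor that lies within the scatter. That step cannot be read further, as compound 1 stands only at a limit: the limit of > 100000 nM in this assay, at which 1 of the 4 values shown sits.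

Open, as far as these compounds go, is whether 4-bromophenyl on the piperazine would behave as it does on the hydrazide. Also open, from the compounds shown here alone, is how a piperazine with no aryl group, a morpholine or a carboxylic acid would fare at this carbonyl.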